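The source may report more compounds than this note shows. Statements on the series, on what has been measured and on what is new or still open speak of the compounds shown alone.

Measured so far in a functional assay on L6 cells (Rattus norvegicus) for inhibition (on this read-out higher numbers stand for weaker inhibition and lower numbers for stronger inhibition), as follows

- compound 1 `CC(C)c1c(C(=O)N(C)Cc2ccccc2)nn(-c2ccc(F)cc2)c1CC[C@@H](O)C[C@@H](O)CC(=O)O` gives 2870 nM
- compound 2 `CC(C)c1c(C(=O)N(C)Cc2cccc(F)c2)nn(-c2ccc(F)cc2)c1CC[C@@H](O)C[C@@H](O)CC(=O)O` gives 1900 nM
- compound 3 `CC(C)c1c(C(=O)NCC2CCCCC2)nn(-c2ccc(F)cc2)c1OC[C@@H](O)C[C@@H](O)CC(=O)O` is reported as "not determined" (no result reported)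

Compound 3 therefore offers no number to start from. Compound 4 `Cc1ccccc1CNC(=O)c1nn(-c2ccc(F)cc2)c(OC[C@@H](O)C[C@@H](O)CC(=O)O)c1C(C)C` differs from compound 3 by 2-methylphenyl in place of cyclohexyl on a saturated chain carbon bound to an amide-type nitrogen and so carries 2-methylphenyl in place of cyclohexyl. For the measured compounds named here, the only measured step is a 1.5-fold lower number from compound 1 to compound 2 (0.18 log units; within the scatter) and it is a different change, so it gives no size or direction for this one. Going by the values given here, no step from compound 3 can be expected, and the estimate rests only on the general level of compound 1 at 2870 nM and compound 2 at 1900 nM in this assay as loose guides. Compound 4 is estimated at 1800 nM with 350 nM to 9000 nM as the expected range, which is deliberately wide.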

Compound 4, half-maximal inhibitory concentration: 2850 nM
Estimate against measurement, compound 4: 1.6-fold (0.20 log units) below; the measured number falls inside the stated range.
By their numbers in this assay, from the lowest: compounds 2, 4 and 1 (each within the scatter of the next).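

For the compounds shown here, compound 3 offers no number in this assay, so no step to compound 4 can be read. Left open is how 2-methylphenyl compares with cyclohexyl in this place. No evidence bears on this result.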